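The compounds below may be only part of what the source reports. "The series", "measured", "known", "first", "only" and "open" are said of these compounds alone.

Working notes on the series.

Of the compounds shown here, two have been measured in an assay on RBL-1 cells for inhibition of Polyunsaturated fatty acid 5-lipoxygenase (Rattus norvegicus); on this read-out higher numbers stand for weaker inhibition and lower numbers for stronger inhibition. Compound 1, `CC1CN(c2cccc(F)n2)NC(=O)N1`, gives 6600 nM. Compound 2, `O=C1NCCN(c2cccc(Br)n2)N1`, gives 3500 nM. Compound 2 thus stands at the lower of the two numbers, but the gap to compound 1 lies within the usual scatter, so the two cannot be ranked against each other. Compounds 1 and 2 differ in two places at once, so no single-change step can be read from them.

Compound 3, `CC1CN(c2cccc(Br)n2)NC(=O)N1`, remains to be measured in this assay. It differs from compound 2 in one place: methyl in place of hydrogen on a saturated ring carbon. Among the compounds with values here, no measured pair isolates this change, and compound 1 carries the methyl together with a different halogen, so it gives no clean guide. The expectation is a step from compound 2 to compound 3 of a 1.3-fold higher number from compound 2 to compound 3 (0.11 log units; within the scatter), that is, no shift beyond the scatter. Compound 3 is therefore estimated at 4500 nM, with a range from 2000 nM to 10000 nM.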

Compound 3, half-maximal inhibitory concentration: 2400 nM
Beside the measured number, compound 3's estimate is 1.9-fold (0.27 log units) above it, and the stated range covers the measured number.
By their numbers in this assay, from the lowest: compounds 3, 2 and 1 (each within the scatter of the next, the first and the last beyond it).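

In this assay, within the data shown here, methyl in place of hydrogen on the saturated ring carbon gives a 1.5-fold lower number from compound 2 to compound 3 (0.16 log units; within the scatter) and so produces no shift that can be told from the scatter, which is the first clean reading at this position. Among these compounds, with that methyl held constant, bromo in place of fluoro on the aromatic carbon gives a 2.8-fold lower number from compound 1 to compound 3 (0.44 log units; beyond the scatter) as the first single change beyond the scatter, though the step is modest. No measured evidence bears on the origin of either step.

Going by these compounds, whether the saturated ring carbon also accepts an ethyl, a hydroxymethyl or an aminomethyl group remains open. On the aromatic carbon, the compounds shown also leave open how chloro, nitrile or methoxy would compare with bromo on the shared core.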